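Lengthening a Hydroxyl-Bearing Chain in a Cytotoxicity Series

The source may report more compounds than this note shows. Statements on the series, on what has been measured and on what is new or still open speak of the compounds shown alone.

For the measured compounds named here, compound 2 `COc1nc2ccc(Br)cc2cc1C(c1ccccc1)n1cc(CO)nn1` gives 4.65% in an ADME assay on PC-3 cells (Homo sapiens) for cytotoxicity, read by sulforhodamine B assay, with a stated time of 48 h, tested at 10 uM; on this read-out higher numbers stand for more inhibition at the one concentration tested (going by the name of the read-out) and lower numbers for less inhibition; of the two numbers measured so far it is the lower, yet compound 1 `CCCCc1cn(C(c2ccccc2)c2cc3cc(Br)ccc3nc2OC)nn1`, which gives 5.54%, lies within the scatter of it. Going by the values given here, the only measured step, a number 0.9 percentage points lower from compound 1 to compound 2 (within the scatter), concerns the same place that changes in compound 3 `COc1nc2ccc(Br)cc2cc1C(c1ccccc1)n1cc(CCCCCO)nn1`: 4-hydroxybutyl in place of hydroxy on a saturated chain carbon bound to an aromatic carbon. That step gave no movement beyond the scatter, and nothing else measured here speaks to a longer chain. Compound 3 is therefore expected to give 6%, within -4% to 18%, an expected step of a number 1.4 percentage points higher from compound 2 to compound 3 (within the scatter) that stays within the scatter.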

Compound 3, a percentage reported as inhibition, at one concentration (the size of the read-out at that concentration, not a potency): 12.9%
The estimate for compound 3 lay 6.9 percentage points below the measured number, within the range that was stated.
By their numbers in this assay, from the lowest: compounds 2, 1 and 3 (each within the scatter of the next).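

In this assay, a much longer group at this place, 4-hydroxybutyl in place of hydroxy on a saturated chain carbon bound to an aromatic carbon, gives a number 8.3 percentage points higher from compound 2 to compound 3 (within the scatter). Hydroxymethyl in place of hydrogen on a saturated chain carbon, four bonds along the chain from an aromatic carbon, gives a number 7.4 percentage points higher from compound 1 to compound 3 (within the scatter), so neither change moves the number beyond the scatter. No evidence is available to explain these results.

From the compounds shown here alone, whether a longer chain, or an amine or a carboxylic acid in place of the hydroxy, would move the number beyond the scatter remains open.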